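Swapping a Piperazine Carbamate for an Acetamide Chain

This account rests on a few compounds, and the source may have more. Where it says the series, first, only, none or still open, it means among the compounds named here.

Measured compounds:
- compound 1, `CS(=O)(=O)N1CCN(CC(O)CN2CCC(CNC(=O)c3cccc4[nH]c(C5CC5)nc34)CC2)CC1`: 0.501 nM
- compound 2, `COC(=O)N1CCN(CCN2CCC(CNC(=O)c3cccc4[nH]c(C(C)C)nc34)CC2)CC1`: 1.59 nM

Compound 1 and compound 2 share a core and were both tested in an assay on isolated protein for binding affinity to 5-hydroxytryptamine receptor 4 (Homo sapiens); a lower number here means a stronger inhibitor, a higher number a weaker inhibitor. Compound 2 has the higher of the two numbers; its nearest neighbour is compound 1, which gives 0.501 nM, a gap that lies beyond the usual scatter of such measurements.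

Compound 3, `CC(=O)N(C)CC(O)CN1CCC(CNC(=O)c2cccc3[nH]c(C(C)C)nc23)CC1`, is not yet measured in this assay. It differs from compound 2 in one place: 2-(acetyl(methyl)amino)-1-hydroxyethyl in place of (4-(methoxycarbonyl)piperazin-1-yl)methyl on a saturated chain carbon bound to an amine nitrogen in a ring. The change keeps the shared core untouched and alters only the side chain on the ring amine. Without a measured step for this kind of change, the expectation is a step of modest size, likely within the scatter, in either direction. Compound 3 is estimated at 1.6 nM, with a range from 0.4 nM to 6 nM, which is expected to correspond to a step of a 1.0-fold higher number from compound 2 to compound 3 (0.00 log units; within the scatter).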

Compound 3, inhibition constant: 3.98 nM
Compound 3: middle estimate off by 2.5-fold (0.40 log units), on the low side; the measured number falls inside the stated range.
By their numbers in this assay, from the lowest: compound 1; then compound 2; then compound 3.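

In this assay, replacing (4-(methoxycarbonyl)piperazin-1-yl)methyl with 2-(acetyl(methyl)amino)-1-hydroxyethyl gives a 2.5-fold higher number from compound 2 to compound 3 (0.40 log units; beyond the scatter) and shows that the side chain at this place can shift the number, though only modestly. The six-membered ring of the departing group is not essential for strong binding, since compound 3 has no ring in this side chain and still gives 3.98 nM in this assay. No measurement shown here explains why the number rises.

The swap changes the ring, the chain, and the counts of hydrogen-bond donors and acceptors together, so the compounds shown cannot assign the step to any one of these features. As far as these compounds go, how a carboxylic acid or a longer chain would behave at this place remains open.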